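Bromo to cyanosulfanyl on the fused core

The source may hold more compounds than are shown below. What is called first, only, known or untested is meant among the compounds shown, and "the series" means these compounds.

Working notes on a small series sharing one fused core. Compound 1 `Fc1ccc(-c2nc3sc(Cc4ccc(Cl)cc4)nn3c2Br)cc1` carries a fluorophenyl group on that core; in a functional assay on L1210 cells (Mus musculus) for cytotoxicity, with a stated time of 48 h (on this read-out higher numbers stand for weaker inhibition and lower numbers for stronger inhibition), compound 1 returns only a limit, > 250000 nM, and no number. Compound 2 `O=c1oc2ccccc2cc1-c1nc2sc(Cc3ccc(Cl)cc3)nn2c1Br` carries a different aryl group in the same position of the core, and in this assay compound 2 gives 5200 nM. For the measured compounds named here, this is the only numeric value shown so far for the series. Going by the values given here, the one other value, for compound 1, is the limit (the limit of > 250000 nM in this assay, at which 1 of the 2 values shown sits). Compound 2 therefore stands alone as the single measured point from which the next step is judged.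

Compound 3 `N#CSc1c(-c2cc3ccccc3oc2=O)nc2sc(Cc3ccc(Cl)cc3)nn12` differs from compound 2 by cyanosulfanyl in place of bromo on an aromatic carbon. Among the compounds with values here, no measured pair shows what such a swap does, so its size is not known from the data. The expectation is a step that stays within the scatter or at most a modest shift, in either direction, with the expected step of a 1.2-fold lower number from compound 2 to compound 3 (0.06 log units; within the scatter). Compound 3 is estimated in this assay at 4500 nM, with a range from 1200 nM to 18000 nM.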

Compound 3, half-maximal inhibitory concentration: 1300 nM
For compound 3 the middle estimate is 3.5-fold (0.54 log units) above the measured one; measured number inside the range.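

In this assay, cyanosulfanyl in place of bromo on an aromatic carbon gives a 4.0-fold lower number from compound 2 to compound 3 (0.60 log units; beyond the scatter), the first step measured at this position of the shared core. Compounds 1 and 2 both carry bromo there and differ only in the aryl group, so they could not show that this position responds to a change; the pair of compound 2 and compound 3 shows that it does, and that bromo can be replaced without loss on this read-out, with the entering group bringing more heavy atoms, a triple bond outside aromatic rings and hydrogen-bond acceptors. Nothing in the data shown accounts for the size of this step.

The compounds shown leave open which part of the cyanosulfanyl group matters, since a single pair cannot separate the sulfur from the nitrile end, and a methylsulfanyl group, a directly attached nitrile or an amine at this position would bear on that. Going by these compounds, it is also open whether the swap carries over to the fluorophenyl series, where compound 1 gives only a limit, > 250000 nM.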